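Dropping the Chloro from the Hydroxyphenyl Amide

A few compounds are considered here, and "the series" means these few. Any claim that something is new, unique, unknown or untested is made for them only; others in the source may bear on it.

In an assay on isolated protein for inhibition of coagulation factor XII (Homo sapiens), read by HPLC, with stated times of 10 min and 30 min (a lower number here means a stronger inhibitor, a higher number a weaker inhibitor), the three measured compounds gave:
compound 1, `O=C(Nc1cc(Cl)ccc1O)c1cc2cc(Cl)cc(Br)c2oc1=O`, 5000 nM
compound 2, `O=C(Nc1ccc(Cl)cc1O)c1cc2cc(Cl)cc(Br)c2oc1=O`, 8000 nM
compound 3, `O=C(Nc1cccc(O)c1)c1cc2cc(Cl)cc(Br)c2oc1=O`, 34000 nM

Compound 2 stands second highest of the three numbers. Its nearest neighbour is compound 1, with a 1.6-fold higher number from compound 1 to compound 2 (0.20 log units; within the scatter), a gap that stays within the scatter. Its furthest is compound 3, with a 4.3-fold higher number from compound 2 to compound 3 (0.63 log units; beyond the scatter), a modest loss that goes beyond the scatter; the same direction shows in a 6.8-fold higher number from compound 1 to compound 3 (0.83 log units; beyond the scatter).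

Compound 4, `O=C(Nc1ccccc1O)c1cc2cc(Cl)cc(Br)c2oc1=O`, differs from compound 2 in one place: hydrogen in place of chloro on an aromatic carbon. Only compound 3 bears on this, and only in part, since compound 3 also lacks the chloro on its ring while carrying the hydroxy group in a different position. The step from compound 2 to compound 3 was a modest loss, so a loss of similar or smaller size is expected here, though a step within the scatter cannot be ruled out.

Compound 4 is therefore estimated at 15000 nM in this assay, with a range from 6000 nM to 40000 nM, which means an expected step of a 1.9-fold higher number from compound 2 to compound 4 (0.27 log units; within the scatter).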

Compound 4, half-maximal inhibitory concentration: 7000 nM
For compound 4 the middle estimate is 2.1-fold (0.33 log units) above the measured one; the measured number falls inside the stated range.
By their numbers in this assay, from the lowest: compounds 1, 4 and 2 (each within the scatter of the next); then compound 3.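

In this assay, the chloro at this position, para to a large group and meta to the hydroxy group, can give way to hydrogen with no effect that the data can distinguish: a 1.1-fold lower number from compound 2 to compound 4 (0.06 log units; within the scatter). Compound 1, which carries its chloro elsewhere on the ring, gives the same reading, with a 1.4-fold higher number from compound 1 to compound 4 (0.15 log units; within the scatter), so for these compounds neither chloro placement stands apart from the 2-hydroxyphenyl amide without chloro. The earlier steps shown here to compound 3 changed the chloro and the hydroxy position together, whereas this pair isolates the hydroxy position, and a 4.9-fold lower number from compound 3 to compound 4 (0.69 log units; beyond the scatter) shows that 2-hydroxyphenyl and 3-hydroxyphenyl do differ beyond the scatter.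

The data offer no explanation for either the tolerance of the chloro change or the effect of moving the hydroxy group. Going by these compounds, it remains open whether a fluoro, a methyl or an amine at the former chloro position would stay within the same range, and whether a methoxy group or an amine could stand in for the hydroxy group on the 2-hydroxyphenyl ring.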